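Swapping Furan for Thiophene in Chalcone-Like Epoxides

A few compounds are considered here, and "the series" means these few. Any claim that something is new, unique, unknown or untested is made for them only; others in the source may bear on it.

Measured compounds:
Compound 1 `O=C(/C=C/c1ccco1)c1ccccc1OCC1CO1` — 48300 nM
Compound 2 `O=C(/C=C/c1cccs1)c1ccccc1OCC1CO1` — 7710 nM
Compound 3 `O=C(/C=C/c1ccc(OCC2CO2)cc1)c1ccco1` — 17300 nM

All three were tested in a functional assay on MDA-MB-468 cells (Homo sapiens) for inhibition, read by CCK-8 assay and cell counting, with a stated time of 2 days; on this read-out lower numbers stand for stronger inhibition and higher numbers for weaker inhibition. Compound 1 gives 48300 nM and compound 2 gives 7710 nM, a change described by thiophen-2-yl in place of furan-2-yl on a double-bonded chain carbon bound to a double-bonded chain carbon. That change produced a 6.3-fold lower number from compound 1 to compound 2 (0.80 log units; beyond the scatter). Compound 3 has the same atoms as compound 1, joined differently. In this assay compound 3 gives 17300 nM. How the core of compound 3 differs from the core of compound 1 is not broken down here, beyond the plain numbers, which place compound 3 between the other two.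

Compound 4 `O=C(/C=C/c1ccc(OCC2CO2)cc1)c1cccs1` has not yet been measured in this assay. It differs from compound 3 by thiophen-2-yl in place of furan-2-yl on a carbonyl carbon. Within the data shown here, this is the same kind of change as the one from compound 1 to compound 2, but not the same: there the new ring sat on a double-bonded chain carbon bound to a double-bonded chain carbon, whereas here it sits on a carbonyl carbon whose other neighbour is a double-bonded chain carbon. Among the measured compounds shown here, only one such step has been seen, and at a different place, so its size is an uncertain guide.

The expected step from compound 3 to compound 4 is a 2.9-fold lower number from compound 3 to compound 4 (0.46 log units; beyond the scatter), somewhat smaller than the earlier one because a 6.3-fold lower number from compound 1 to compound 2 (0.80 log units; beyond the scatter) came from a different place on the chain. For compound 4 the estimated value in this assay is 6000 nM, with a likely range from 2000 nM to 17000 nM.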

Compound 4, half-maximal inhibitory concentration: 6300 nM
Beside the measured number, compound 4's estimate is 1.1-fold (0.02 log units) below it; the measured number falls inside the stated range.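

Placing thiophen-2-yl in place of furan-2-yl on a carbonyl carbon gave a 2.7-fold lower number from compound 3 to compound 4 (0.44 log units; beyond the scatter) in this assay, so the swap that lowered the number on the core of compound 1 also lowered it on the core of compound 3. Set side by side, the two steps point the same way and their sizes cannot be told apart: the same change on two cores in this assay, a 6.3-fold lower number (0.80 log units; beyond the scatter) from compound 1 to compound 2 and a 2.7-fold lower number (0.44 log units; beyond the scatter) from compound 3 to compound 4, 2.3-fold (0.36 log units) apart, within the scatter of two such steps. This shows that, in these two matched pairs, the swap carried over from one core to the other with a step of comparable size, even though the ring sits at a different place on the chain in each pair, but two pairs make no general rule, and the numbers do not explain why the swap lowers the number.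

On these data alone, what remains open is whether the same swap would give a similar step on a core carrying a different substituent, such as an amine or a carboxylic acid on the ring, or a longer chain in place of the present link. The compounds shown also cannot say how any five-membered ring other than furan-2-yl and thiophen-2-yl would behave at these two places.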